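Bromo for Fluoro on the Aryl Ring of Compound 2

The compounds below may be only part of what the source reports. "The series", "measured", "known", "first", "only" and "open" are said of these compounds alone.

Measured compounds:
compound 1, `Clc1ccc(Cc2nn3cc(-c4ccc(Br)cc4)nc3s2)cc1`, gives > 250000 nM
compound 2, `O=Cc1c(-c2ccc(F)cc2)nc2sc(Cc3ccc(Cl)cc3)nn12`, gives 17000 nM

In an ADME assay on CCRF-CEM cells (Homo sapiens) for cytotoxicity, with a stated time of 72 h (a higher number here means a weaker inhibitor, a lower number a stronger inhibitor), compound 2 gives 17000 nM, the only numeric value among the two compounds shown. Compound 1 sits at the limit of > 250000 nM in this assay, at which 1 of the 2 values shown sits, which is a limit of the assay and not a number. Compound 3, `O=Cc1c(-c2ccc(Br)cc2)nc2sc(Cc3ccc(Cl)cc3)nn12`, has not yet been measured in this assay. It differs from compound 2 by bromo in place of fluoro on an aromatic carbon. Among the measured compounds shown here, no step between two measured compounds isolates this change, so no measured size is available for it; the expected step in this assay from fluoro to bromo is small, within the usual scatter, in no particular direction. Compound 3 is therefore estimated at 15000 nM, between 6000 nM and 40000 nM. The expected step of a 1.1-fold lower number from compound 2 to compound 3 (0.05 log units; within the scatter) amounts to no change beyond the scatter.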

Compound 3, half-maximal inhibitory concentration: 4000 nM
For compound 3 the middle estimate is 3.8-fold (0.57 log units) above the measured one; measured number below the stated range.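

In this assay, bromo in place of fluoro on an aromatic carbon, para to a large group, gives a 4.3-fold lower number from compound 2 to compound 3 (0.63 log units; beyond the scatter), which shows that the halogen at this place is not a silent choice. With the 4-bromophenyl group held fixed, formyl in place of hydrogen on an aromatic carbon gives an at least 62-fold lower number from compound 1 to compound 3 (1.79 log units; beyond the scatter), a large step and the first measured sign that the formyl group counts for much in this series. Compound 1 stands at a limit of the assay and not at a number, so this step gives a bound rather than a size: the limit of > 250000 nM in this assay, at which 1 of the 3 values shown sits.

The compounds shown leave open whether chloro or a methoxy group at the same place would fall in line with fluoro or with bromo. They also leave open whether a carboxylic acid or a hydroxymethyl group could take the place of the formyl group.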